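A few compounds are considered here, and "the series" means these few. Any claim that something is new, unique, unknown or untested is made for them only; others in the source may bear on it.

The series shares one core, seen in compound 1 `Cn1ccc2cc(-c3ccc4oc(Cc5ccccc5)nc4c3)ccc21`, which in an assay on HEK293 cells for inhibition of Fatty-acid amide hydrolase 1 (Homo sapiens), read by fluorescence (a lower number here means a stronger inhibitor, a higher number a weaker inhibitor), gives 488 nM. Compound 2 `Cn1ccc2cc(-c3ccc4oc(Nc5ccc(F)cc5)nc4c3)ccc21` gives 99 nM in this assay, and compound 3 `Cn1ccc2cc(-c3ccc4oc(Nc5ccccn5)nc4c3)ccc21` gives 186 nM. Among the three numbers, compound 3 stands second highest; its nearest neighbour is compound 2, with a 1.9-fold higher number from compound 2 to compound 3 (0.27 log units; within the scatter), while compound 1 lies furthest, with a 2.6-fold lower number from compound 1 to compound 3 (0.42 log units; beyond the scatter). Compound 4 `C[C@@H]1CN(c2nc3cc(-c4ccc5c(ccn5C)c4)ccc3o2)C[C@H](C)O1` is not yet measured. Its change from compound 3 is 2,6-dimethylmorpholin-4-yl in place of (pyridin-2-yl)amino on an aromatic carbon. Going by the values given here, no measured step exchanges an arylamino group for a saturated ring amine at this carbon of the core. The steps that come closest are a 4.9-fold lower number from compound 1 to compound 2 (0.69 log units; beyond the scatter) and a 2.6-fold lower number from compound 1 to compound 3 (0.42 log units; beyond the scatter), both modest and both moving from benzyl to an arylamino group, while a 1.9-fold higher number from compound 2 to compound 3 (0.27 log units; within the scatter) shows that swapping one aromatic ring for another on that nitrogen stays within the scatter. These offer no direct guide to the dimethylmorpholine, so for compound 4 a step no larger than modest is expected, direction open with a slight lean toward a higher number: a 1.5-fold higher number from compound 3 to compound 4 (0.18 log units; within the scatter). Compound 4 is therefore estimated at 280 nM, with a likely range from 80 nM to 1000 nM.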

Compound 4, half-maximal inhibitory concentration: 168 nM
Estimate against measurement, compound 4: 1.7-fold (0.22 log units) above, and the stated range covers the measured number.
By their numbers in this assay, from the lowest: compounds 2, 4 and 3 (each within the scatter of the next); then compound 1.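

Working in this assay, replacing the arylamino group on the aromatic carbon of the five-membered aromatic ring with a six-membered non-aromatic ring leaves the number within the scatter (a 1.1-fold lower number from compound 3 to compound 4 (0.04 log units; within the scatter)), and the same holds against the fluorinated aryl amine (a 1.7-fold higher number from compound 2 to compound 4 (0.23 log units; within the scatter)). Among these compounds, therefore, neither an aromatic ring on the substituent nor a hydrogen-bond donor is needed to stay level with compound 2 and compound 3, since 2,6-dimethylmorpholin-4-yl has 0 hydrogen-bond donors. The step from benzyl (a 2.9-fold lower number from compound 1 to compound 4 (0.46 log units; beyond the scatter)) is beyond the scatter, so all three nitrogen-linked groups now stand apart from the carbon-linked benzyl, with no compound shown going against this, although nothing at hand explains the pattern.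

The compounds shown leave open what the two methyl groups, the ring oxygen and the 2 defined stereocentres each contribute, as plain morpholin-4-yl, piperidin-1-yl and the other stereoisomers of the 2,6-dimethylmorpholin-4-yl group would separate these parts. They also leave open whether a small open-chain amine such as dimethylamino would stay level with these groups, or whether a saturated ring amine bearing a carboxylic acid would.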